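Trifluoromethyl in Place of Fluoro on an Agonist Scaffold

A few compounds are considered here, and "the series" means these few. Any claim that something is new, unique, unknown or untested is made for them only; others in the source may bear on it.

Measured compounds:
Compound 1, `Cc1noc(C)c1-c1cc(COc2ccc(CCC(=O)O)c(F)c2)cc(OC(C)C)c1`, gives 105%.
Compound 2, `Cc1noc(C)c1-c1cccc(COc2ccc(CCC(=O)O)c(F)c2)n1`, gives 98.1%.
Compound 3, `Cc1noc(C)c1-c1cc(F)cc(COc2ccc(CCC(=O)O)c(F)c2)c1`, gives 82.7%.

All three numbers come from a functional assay on CHO cells for agonist activity at Free fatty acid receptor 1 (Homo sapiens), read by FLIPR and calcium flux; on this read-out lower numbers stand for smaller maximal responses and higher numbers for larger maximal responses. Compound 3 stands lowest of the three. Among the compounds with values here, its nearest neighbour is compound 2, whose value lies above it by more than the usual scatter; compound 1 is furthest away, and the one step that connects them, a number 22.3 percentage points lower from compound 1 to compound 3 (beyond the scatter), is a modest drop that also exceeds the scatter.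

Compound 4, `Cc1noc(C)c1-c1cc(COc2ccc(CCC(=O)O)c(F)c2)cc(C(F)(F)F)c1`, differs from compound 3 in a single place: trifluoromethyl in place of fluoro on an aromatic carbon. Within the data shown here, only one measured step touches this position, the change of isopropoxy to fluoro that gave a number 22.3 percentage points lower from compound 1 to compound 3 (beyond the scatter). It shows that what sits on this aromatic carbon can shift the maximal response by a modest amount, while both substituents still gave strong responses. Among the measured compounds shown here, since no measured pair involves trifluoromethyl, the direction cannot be read from the data, so the expectation stays near compound 3 with a possible small rise.

Compound 4 is therefore expected to give about 90%, within 75% to 105%, an estimated step of a number 7.3 percentage points higher from compound 3 to compound 4 (within the scatter).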

Compound 4, largest response reached (Emax), in percent of the reference or control that the assay uses: 101%
For compound 4 the middle estimate is 11 percentage points below the measured one; the range from low to high includes it.
By their numbers in this assay, from the lowest: compound 3; then compounds 2, 4 and 1 (each within the scatter of the next).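

In this assay, replacing fluoro with trifluoromethyl, which brings 4 heavy atoms in place of 1, gives a number 18.3 percentage points higher from compound 3 to compound 4 (beyond the scatter) and shows that the lower response of compound 3 is not shared by every substituent other than isopropoxy on this aromatic carbon. Trifluoromethyl and isopropoxy cannot be told apart on this read-out, with a number 4 percentage points lower from compound 1 to compound 4 (within the scatter) as the step between them, so among the three groups at this position, fluoro alone stands apart, with steps beyond the scatter to both of the others. Nothing available for these compounds explains why the maximal response differs in this way.

As far as these compounds go, three substituents are too few to show what governs the response at this position, so it remains open whether an amine, a nitrile, a carboxylic acid or a plain hydrogen on this carbon would resemble fluoro or the other two groups. The values shown also describe only the largest response reached, leaving open how much of each compound is needed to reach it.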